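Benzothiophene replaces isopropylphenyl on the triazole-linked hydroxamic acid series

The compounds below may be only part of what the source reports. "The series", "measured", "known", "first", "only" and "open" are said of these compounds alone.

Working notes on a small set sharing one hydroxamic acid core. Compound 1 `Cc1ccc(-c2nc(CNc3ccc(C(=O)NO)cc3)n(-c3ccccc3)n2)o1` gives 60.7% in an assay on Sf9 cells for inhibition of protein deacetylase HDAC6 (Homo sapiens), read by fluorescence, with a stated time of 40 min, tested at 100 nM; on this read-out higher numbers stand for more inhibition at the one concentration tested (going by the name of the read-out) and lower numbers for less inhibition. Compound 2 `COc1ccc(-c2nc(CNc3ccc(C(=O)NO)cc3)n(-c3ccccc3)n2)cc1` gives 77.6% in this assay, and compound 3 `CC(C)c1ccc(-c2nc(CNc3ccc(C(=O)NO)cc3)n(-c3ccccc3)n2)cc1` gives 27.6%. Compound 3 stands lowest of the three numbers; its nearest neighbour is compound 1, its furthest compound 2, and both gaps are beyond the scatter: a number 33.1 percentage points lower from compound 1 to compound 3 (beyond the scatter) and a number 50 percentage points lower from compound 2 to compound 3 (beyond the scatter), while a number 16.9 percentage points higher from compound 1 to compound 2 (beyond the scatter).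

Compound 4 `O=C(NO)c1ccc(NCc2nc(-c3cc4ccccc4s3)nn2-c2ccccc2)cc1` has not yet been measured in this assay. It differs from compound 3 in one place: 1-benzothiophen-2-yl in place of 4-isopropylphenyl on an aromatic carbon.

Among the compounds with values here, two measured steps bear on this. The step into compound 3 from compound 1 swapped a five-membered ring with a hetero atom for 4-isopropylphenyl and fell by a large amount; the step from compound 2 to compound 3 swapped methoxy for isopropyl and fell further still. Compound 4 removes the 4-isopropylphenyl entirely and brings in a group that again contains a five-membered aromatic ring with 1 hetero atom. Within the data shown here, a rise back toward the levels of compounds 1 and 2 is therefore expected, though a fused group of this kind has no direct precedent here, so the range is wide. The estimate for compound 4 is 55%, between 30% and 80%, meaning an expected step of a number 27.4 percentage points higher from compound 3 to compound 4 (beyond the scatter).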

Compound 4, a percentage reported as inhibition, at one concentration (the size of the read-out at that concentration, not a potency): 65.5%
Compound 4: middle estimate off by 10.5 percentage points, on the low side; the measured number falls inside the stated range.
By their numbers in this assay, from the lowest: compound 3; then compounds 1 and 4 (each within the scatter of the next); then compound 2.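

At this position, on the aromatic carbon between two ring nitrogen atoms, this assay gives a number 37.9 percentage points higher from compound 3 to compound 4 (beyond the scatter), although 1-benzothiophen-2-yl and 4-isopropylphenyl have the same heavy-atom count, so that count alone does not set the read-out in this pair. The fused group is accepted here: the series shows a number 4.8 percentage points higher from compound 1 to compound 4 (within the scatter), which places the two groups with a five-membered aromatic ring with 1 hetero atom level with each other, while a number 12.1 percentage points lower from compound 2 to compound 4 (beyond the scatter) shows that this ring type does not by itself give the highest number, as the 4-methoxyphenyl of compound 2 goes against any such pattern. No measurement at hand explains why these groups differ in this way.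

Open, going by these compounds, is whether the sulfur matters, which a comparison of 1-benzothiophen-2-yl with benzofuran-2-yl or naphthalen-2-yl would address. Also open, on these data alone, is how far the large fall seen with 4-isopropylphenyl extends to other groups on that phenyl ring, such as an amine, a carboxylic acid or a longer alkyl chain, or to an unsubstituted phenyl.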